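Swapping the aryl ether on a second core

The compounds below may be only part of what the source reports. "The series", "measured", "known", "first", "only" and "open" are said of these compounds alone.

Compound 1 `NC1=NC2(CCOCC2)N(OCCCOc2ccccc2Cl)C(N)=N1` and compound 2 `NC1=NC2(CCOCC2)N(OCCCOc2cccc(Br)c2)C(N)=N1` share one core and differ only in the aryl group carried on the ether oxygen. In a functional assay on MDA-MB-231 cells (Homo sapiens) for antiproliferative activity, read by MTT assay, with a stated time of 72 h (a higher number here means a weaker inhibitor, a lower number a stronger inhibitor), compound 1 gives 1430 nM, while compound 2 gives 400 nM. The change 3-bromophenyl in place of 2-chlorophenyl on an oxygen on a saturated carbon therefore produced a step of a 3.6-fold lower number from compound 1 to compound 2 (0.55 log units; beyond the scatter), a modest but real improvement.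

Compound 3 `NC1=NC2(CCSCC2)N(OCCCOc2ccccc2Cl)C(N)=N1` is built on a second core; the difference between the two cores is not broken down here. In this assay, going by the values given here, compound 3 gives 80 nM, the lowest of the three numbers so far, clearly separated from both compound 2 and compound 1.

Compound 4 `NC1=NC2(CCSCC2)N(OCCCOc2cccc(Br)c2)C(N)=N1` has not yet been measured. It differs from compound 3 by 3-bromophenyl in place of 2-chlorophenyl on an oxygen on a saturated carbon, the same change, at the same place, that separates compound 2 from compound 1. If that change carries over to the second core, compound 4 is expected to show a step of a 2.7-fold lower number from compound 3 to compound 4 (0.43 log units; beyond the scatter), an expectation resting on the single precedent a 3.6-fold lower number from compound 1 to compound 2 (0.55 log units; beyond the scatter). Compound 4 is accordingly estimated at 30 nM in this assay, with a likely range from 10 nM to 90 nM.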

Compound 4, half-maximal inhibitory concentration: 60 nM
The estimate for compound 4 lay 2.0-fold (0.30 log units) below the measured number; low and high end bracket the measured number.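

In this assay the change from 2-chlorophenyl to 3-bromophenyl on the core of compound 3 gives a 1.3-fold lower number from compound 3 to compound 4 (0.12 log units; within the scatter), so the clear step seen on the core of compound 1 does not reappear on this core. The change therefore did not carry over from one core to the other with the same size, and the two steps differ by more than their scatter: the same change on two cores in this assay, a 3.6-fold lower number (0.55 log units; beyond the scatter) from compound 1 to compound 2 and a 1.3-fold lower number (0.12 log units; within the scatter) from compound 3 to compound 4, 2.7-fold (0.43 log units) apart, beyond the scatter of two such steps. This rests on a single pair of compounds on each core in one cell assay, so it does not show why the steps differ or how the change would behave on any further core.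

The compounds shown carry only these two halogenated aryl groups, all on the same chain. On these data alone, how an unsubstituted phenyl, a pyridine ring, an aryl group bearing an amine or a carboxylic acid, or a longer chain would behave on either core remains open.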